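Working notes: difluorophenyl replacing dimethoxyphenyl on the carbonyl carbon

The compounds below may be only part of what the source reports. "The series", "measured", "known", "first", "only" and "open" are said of these compounds alone.

Measured in a functional assay on SNB-19 cells (Homo sapiens) for cytotoxicity, read by sulforhodamine B assay, with a stated time of 48 h, tested at 0.01 uM; on this read-out lower numbers stand for a stronger effect and higher numbers for a weaker effect at the one concentration tested:
compound 1 `COc1cc(-c2cc(/C=C/C(=O)c3ccc(N)cc3)[nH]n2)cc(OC)c1OC`: 96%
compound 2 `COc1cc(-c2cc(/C=C/C(=O)c3ccc(Cl)c(Cl)c3)[nH]n2)cc(OC)c1OC`: 100%
compound 3 `COc1ccc(C(=O)/C=C/c2cc(-c3cc(OC)c(OC)c(OC)c3)n[nH]2)cc1OC`: 91%

Compound 3 gives the lowest of the three numbers, yet every step to it lies within the scatter: a number 5 percentage points lower from compound 1 to compound 3 (within the scatter) and a number 9 percentage points lower from compound 2 to compound 3 (within the scatter). The step of a number 4 percentage points higher from compound 1 to compound 2 (within the scatter) is likewise within the scatter, so the three compounds are indistinguishable on this read-out.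

Compound 4 `COc1cc(-c2cc(/C=C/C(=O)c3ccc(F)c(F)c3)[nH]n2)cc(OC)c1OC` differs from compound 3 as follows: 3,4-difluorophenyl in place of 3,4-dimethoxyphenyl on a carbonyl carbon. Among the compounds with values here, the steps that bear on it are the exchanges of the aryl group on the carbonyl carbon, all within the scatter. No step beyond the scatter is therefore expected in this assay; the expected step is a number 6 percentage points higher from compound 3 to compound 4 (within the scatter). Compound 4 is estimated at 97%, within 88% to 104%.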

Compound 4, a percentage reported as activity, at one concentration (the size of the read-out at that concentration, not a potency): 89%
Beside the measured number, compound 4's estimate is 8 percentage points above it, within the range that was stated.
By their numbers in this assay, from the lowest: compounds 4, 3, 1 and 2 (each within the scatter of the next, the first and the last beyond it).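

At the aryl group on the carbonyl carbon, the only step beyond the scatter among these compounds in this assay is a modest one: a number 11 percentage points lower from compound 2 to compound 4 (beyond the scatter). The other two exchanges stay within the scatter: a number 2 percentage points lower from compound 3 to compound 4 (within the scatter) and a number 7 percentage points lower from compound 1 to compound 4 (within the scatter), so 3,4-difluorophenyl separates only from 3,4-dichlorophenyl. Nothing available accounts for that step.

Open, from the compounds shown here alone, is whether a pyridyl or a 4-fluorophenyl group on the carbonyl carbon would give a lower number in this assay. Also open, going by these compounds, is whether the separation of compound 4 from compound 2 holds at other concentrations.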